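The source may report more compounds than this note shows. Statements on the series, on what has been measured and on what is new or still open speak of the compounds shown alone.

Measured in a functional assay on HepG2 cells (Homo sapiens) for antiproliferative activity, read by MTT assay, with a stated time of 72 h; on this read-out lower numbers stand for stronger inhibition and higher numbers for weaker inhibition:
- compound 1 `COc1ncc(-c2ccc3c(c2)NC(=O)CO3)cc1NS(=O)(=O)c1ccc(F)cc1`: 6590 nM
- compound 2 `COc1ncc(-c2ccc3c(c2)N(C2CC2)C(=O)CO3)cc1NS(=O)(=O)c1ccc(F)cc1`: 14400 nM

Of these two compounds, compound 2 has the higher number, at 14400 nM, so it is the weaker inhibitor of cell growth here. Compound 3 `COc1ccc(N2C(=O)COc3ccc(-c4cnc(OC)c(NS(=O)(=O)c5ccc(F)cc5)c4)cc32)cc1` differs from it in a single place: 4-methoxyphenyl in place of cyclopropyl on an amide-type nitrogen in a ring.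

For the measured compounds named here, only one measured step bears on this change. At the same nitrogen, a cyclopropyl replaces a hydrogen, and the result is a 2.2-fold higher number from compound 1 to compound 2 (0.34 log units; beyond the scatter). That step is modest and points towards weaker inhibition. Going by the values given here, it is also a thin guide, since it compares a group with a hydrogen, and no measured compound carries a ring of the aromatic kind at this nitrogen. A small further rise in the number is therefore expected, probably not clearly beyond the scatter, with real uncertainty in both directions.

The step estimated in this assay is a 1.4-fold higher number from compound 2 to compound 3 (0.14 log units; within the scatter). For compound 3, the estimated value is 20000 nM, with an expected range of 7000 nM to 60000 nM.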

Compound 3, half-maximal inhibitory concentration: 13100 nM
Compound 3: middle estimate off by 1.5-fold (0.18 log units), on the high side; the range from low to high includes it.
By their numbers in this assay, from the lowest: compounds 1, 3 and 2 (each within the scatter of the next, the first and the last beyond it).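

In this assay, replacing cyclopropyl with 4-methoxyphenyl on the amide-type nitrogen gives a 1.1-fold lower number from compound 2 to compound 3 (0.04 log units; within the scatter), so a group of 8 heavy atoms with a six-membered aromatic ring cannot be told apart from a group of 3 heavy atoms with a three-membered ring. Measured against the hydrogen on this nitrogen, 4-methoxyphenyl gives a 2.0-fold higher number from compound 1 to compound 3 (0.30 log units; within the scatter), which is printed as within the scatter, while cyclopropyl gives a 2.2-fold higher number from compound 1 to compound 2 (0.34 log units; beyond the scatter), which is printed as beyond it, so the modest loss seen with cyclopropyl is not clearly shared by the larger group, although the two groups themselves do not separate. Nothing measured here explains why these groups behave alike at this position.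

An unsubstituted phenyl group would show whether the methoxy group on the ring contributes anything, since the aromatic ring and its methoxy group enter together in this change. On these data alone, it also remains open whether a group of another kind on this nitrogen, such as a chain ending in an amine or a carboxylic acid, would move the number beyond the scatter in either direction.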